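Ester to Carbamate at the Linker of Compound 1

The compounds below may be only part of what the source reports. "The series", "measured", "known", "first", "only" and "open" are said of these compounds alone.

In an assay on NIH3T3 cells with Urotensin-2 receptor (Homo sapiens) as the target (a higher number here means that more compound is needed for the effect, a lower number that less compound is needed), compound 1 `Cc1ccccc1C(=O)OC(CCN(C)C)c1ccc(Cl)cc1` gives 1700 nM, the highest of the three numbers, though compound 2 `COc1ccc(C(=O)NC(CCN(C)C)c2ccc(Cl)cc2)cc1` with 1350 nM and compound 3 `CN(C)CCC(NC(=O)c1ccc(N(C)C)cc1)c1ccc(Cl)cc1` with 1350 nM both sit within the scatter of it. Going by the values given here, the one measured step, no change at the digits printed from compound 2 to compound 3 (within the scatter), swaps a group on an aromatic carbon and says nothing about the carbonyl that sits within the shared core. Compound 4 `Cc1ccccc1NC(=O)OC(CCN(C)C)c1ccc(Cl)cc1` differs from compound 1 at exactly that carbonyl: (2-methylphenyl)amino in place of 2-methylphenyl on a carbonyl carbon. Among the compounds with values here, no measured step bears on this change, so the expectation rests on compound 1 alone and stays near its number, with a wide range. Compound 4 is expected to give 1700 nM (range 600 nM to 5000 nM), an estimated step of no change at the digits printed from compound 1 to compound 4 (within the scatter).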

Compound 4, half-maximal effective concentration: 3890 nM
Beside the measured number, compound 4's estimate is 2.3-fold (0.36 log units) below it, within the range that was stated.
By their numbers in this assay, from the lowest: compounds 2, 3 and 1 (each within the scatter of the next); then compound 4.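

Going by these compounds alone, this is the first change measured at this carbonyl carbon, and it shows that the position is not indifferent in this assay: (2-methylphenyl)amino in place of 2-methylphenyl gives a 2.3-fold higher number from compound 1 to compound 4 (0.36 log units; beyond the scatter) and turns the ester into a carbamate. More compound is needed after a swap that adds one nitrogen and one hydrogen-bond donor. Nothing measured here accounts for the shift.

From the compounds shown here alone, it remains open whether the nitrogen itself or its hydrogen matters. A (2-methylphenyl)methylamino group, or a 2-methylbenzyl group, on the same carbonyl carbon could help separate the two.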